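Lengthening the chain of a weak stomach-active cyanoguanidine

This account rests on a few compounds, and the source may have more. Where it says the series, first, only, none or still open, it means among the compounds named here.

Compound 1 `N#CNC(=N)NCCCCn1nc(-c2ccccc2)ccc1=O` gives 77.2 mg/kg in this assay.
Compound 2 `C/N=C(/NC#N)NCCCCn1nc(-c2ccccc2)c(C)cc1=O` reaches only the limit of > 100 mg/kg.
Compound 3 `C/N=C(/NC#N)NCCCCCn1nc(-c2ccccc2)cc(C)c1=O` likewise stops at the limit of > 100 mg/kg.

The read-out here is a functional assay on the whole organism (stomach) with Rattus norvegicus as the target; on this read-out higher numbers stand for an effect only at larger amounts of compound and lower numbers for an effect already at smaller amounts. For the measured compounds named here, compound 1 stands alone: it is the only compound among the three with an actual number, while the other two values are limits of the assay and not numbers. Both of those limits sit at the same level, (the limit of > 100 mg/kg in this assay, at which 2 of the 3 values shown sit), so the shared core appears to be a weak one in this setting.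

Compound 4 `N#CNC(=N)NCCCCCn1nc(-c2ccccc2)ccc1=O` is not yet measured. It differs from compound 1 by a group of 7 heavy atoms (3 carbon, 4 nitrogen; no ring) in place of a group of 6 heavy atoms (2 carbon, 4 nitrogen; no ring), on a saturated chain carbon, four bonds along the chain from an aromatic nitrogen. Going by the values given here, no pair of measured compounds differs in one place only, so no measured step sets a scale for what this change does. Compound 3, which also carries the longer chain together with two further changes, reached only a limit, which gives little room for a gain.

The expectation is that compound 4 lands close to compound 1 or somewhat weaker, with a real chance that only a limit is reported. Compound 4 is estimated at 110 mg/kg, with a range from 50 mg/kg to 300 mg/kg. This estimate means a step of a 1.4-fold higher number from compound 1 to compound 4 (0.15 log units; within the scatter), which is expected to stay within the usual scatter.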

Compound 4, dose for half-maximal effect: > 100 mg/kg
Compound 4 was reported as a limit; the forecaster's own chance of this, stated with the estimate: 55%; the middle value is on the limit's open side.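

For the compounds shown here, compounds 1 and 4 differ in one place only, so this pair gives the first direct reading of the change: a group of 7 heavy atoms (3 carbon, 4 nitrogen; no ring) in place of a group of 6 heavy atoms (2 carbon, 4 nitrogen; no ring), on a saturated chain carbon, four bonds along the chain from an aromatic nitrogen. In this assay the change gives an at least 1.2-fold higher number from compound 1 to compound 4 (0.11 log units; that floor lies within the scatter), which is only a floor and does not show a real loss, although the longer chain brought no visible gain. Compound 4 is reported only as a limit of the assay and not as a number, and it joins most of the series there: the limit of > 100 mg/kg in this assay, at which 3 of the 4 values shown sit.

As far as these compounds go, how far compound 4 lies past that limit stays unknown, so the true size of the step remains open. Also open, from the compounds shown here alone, is whether a shorter chain, or an amine or a carboxylic acid in place of the cyanoguanidine, would bring the number down on this core.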